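Turning one stereocentre in an isobutyl compound

This account rests on a few compounds, and the source may have more. Where it says the series, first, only, none or still open, it means among the compounds named here.

compound 1 `O[C@H]1CO[C@H](COCc2ccccc2)[C@@H](OCc2ccccc2)[C@@H]1OCc1ccccc1` gives > 50000 nM (a limit)
compound 2 `CCC[C@H]1O[C@H](COCc2ccccc2)[C@@H](OCc2ccccc2)[C@H](OCc2ccccc2)[C@H]1O` gives 17400 nM
compound 3 `CC(C)C[C@@H]1O[C@H](COCc2ccccc2)[C@@H](OCc2ccccc2)[C@H](OCc2ccccc2)[C@H]1O` gives > 50000 nM (a limit)

In a functional assay on HeLa cells (Homo sapiens) for antiproliferative activity, read by sulforhodamine B assay (on this read-out higher numbers stand for weaker inhibition of growth and lower numbers for stronger inhibition of growth), compound 3 stands at > 50000 nM as a limit and not a number. Compound 4 `CC(C)C[C@H]1O[C@H](COCc2ccccc2)[C@@H](OCc2ccccc2)[C@H](OCc2ccccc2)[C@H]1O` differs from it only thus: the two compounds have the same atoms and bonds and differ only in configuration as drawn: 1 of 5 stereo elements differ; a stereocentre at a saturated ring carbon is drawn S in compound 3 and R in compound 4 and no group changes. Within the data shown here, two measured steps bear on this. The propyl step shows an at least 2.8-fold lower number from compound 1 to compound 2 (0.45 log units; beyond the scatter) and is the only readable one. The isobutyl step shows a step that the two limits leave unreadable from compound 1 to compound 3 and so gives no size. Neither step changes configuration alone, so the size here is uncertain. Among the measured compounds shown here, compound 2 at 17400 nM is the only measured compound with a number, so a modestly lower number is expected for compound 4. The expected step is an at least 2.0-fold lower number from compound 3 to compound 4 (0.30 log units; that floor lies within the scatter) and it may stay unreadable. For compound 4 the estimated value is 25000 nM with 10000 nM to 50000 nM as the expected range.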

Compound 4, concentration for 50% growth inhibition: 43900 nM
Compound 4: the middle estimate sits 1.8-fold (0.24 log units) below what was measured; the range from low to high includes it.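

In this assay, turning this one stereocentre gives the isobutyl compounds their first true number, yet the step is only a floor: an at least 1.1-fold lower number from compound 3 to compound 4 (0.05 log units; that floor lies within the scatter). The comparison with the compound lacking the isobutyl group is likewise only a floor: an at least 1.1-fold lower number from compound 1 to compound 4 (0.05 log units; that floor lies within the scatter). The firm comparison is between the chains, where methyl in place of hydrogen on the propyl chain gives a 2.5-fold higher number from compound 2 to compound 4 (0.40 log units; beyond the scatter).

Compound 3 is only a limit, which leaves the full size of the configuration step open. Also open, from the compounds shown here alone, is how an amine or a longer chain on this ring carbon would behave.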